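The source may report more compounds than this note shows. Statements on the series, on what has been measured and on what is new or still open speak of the compounds shown alone.

Measured compounds in this study:
compound 1, `O=C(Nc1cccc(-c2oc3cc(-c4ccc(F)cc4)ccc3c(=O)c2O)c1)c1ccc(F)cc1F`
compound 2, `COc1cccc(C(=O)Nc2cccc(-c3oc4cc(-c5ccc(F)cc5)ccc4c(=O)c3O)c2)c1`

In a functional assay on HeLa cells (Homo sapiens) for antiproliferative activity, read by CCK-8 assay, with a stated time of 72 h (a lower number here means a stronger inhibitor, a higher number a weaker inhibitor), compound 1 gives 10700 nM, while compound 2 gives 5650 nM. For the measured compounds named here, compound 2 is the compound from which the present step departs; the only measured step, a 1.9-fold lower number from compound 1 to compound 2 (0.28 log units; within the scatter), lies within the scatter, so compounds 1 and 2 are not told apart by these numbers.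

Compound 3, `Cc1cccc(C(=O)Nc2cccc(-c3oc4cc(-c5ccc(F)cc5)ccc4c(=O)c3O)c2)c1`, differs from compound 2 in a single place: methyl in place of methoxy on an aromatic carbon. Going by the values given here, the one measured step bears on it only loosely, as it also alters the aryl group on the carbonyl carbon, and it was within the scatter. Among the compounds with values here, with no step of this kind measured, compound 3 is expected to remain near compound 2, with a step of a 1.0-fold lower number from compound 2 to compound 3 (0.01 log units; within the scatter) in this assay. Compound 3 is therefore estimated at 5500 nM, within a range from 2500 nM to 12000 nM.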

Compound 3, half-maximal inhibitory concentration: 6650 nM
Compound 3: middle estimate off by 1.2-fold (0.08 log units), on the low side; the measured number falls inside the stated range.
By their numbers in this assay, from the lowest: compounds 2, 3 and 1 (each within the scatter of the next).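

In this assay, putting 3-methylphenyl in place of 3-methoxyphenyl on the carbonyl carbon gives a 1.2-fold higher number from compound 2 to compound 3 (0.07 log units; within the scatter), so this position tolerates the loss of the methoxy oxygen without a change that these numbers can resolve. The comparison with the 2,4-difluorophenyl group gives a 1.6-fold lower number from compound 1 to compound 3 (0.21 log units; within the scatter), which means that the three aryl groups on this carbonyl carbon are not told apart in this assay. Nothing measured on these compounds offers an explanation for this result.

As far as these compounds go, what remains open is whether any group at this ring position can move the number beyond the scatter, for instance an amine, a carboxylic acid or a longer chain such as butoxy. From the compounds shown here alone, it is also open whether the same exchange would behave alike on a different core.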